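A few compounds are considered here, and "the series" means these few. Any claim that something is new, unique, unknown or untested is made for them only; others in the source may bear on it.

Measured so far in a physicochemical assay for solubility, in phosphate buffer, with a stated time of 18 h; a lower number here means a less soluble compound, a higher number a more soluble compound:
- compound 1 `Cc1nc(C(C)(C)C)nc2nc(N)c(C#N)c(N)c12`: 37000 nM
- compound 2 `CC(C)(C)c1nc(CCCCC#N)c2c(N)c(C#N)c(N)nc2n1`: 16000 nM
- compound 3 `CC(C)(C)c1nc(CCCCCC#N)c2c(N)c(C#N)c(N)nc2n1`: 6000 nM

Compound 3, at 6000 nM, is the lowest of the three, with compound 2 nearest and compound 1 furthest. Compound 4 `CC(C)(C)c1nc(-c2nccs2)c2c(N)c(C#N)c(N)nc2n1` carries 1,3-thiazol-2-yl in place of 5-cyanopentyl on an aromatic carbon of the shared core (1,3-thiazol-2-yl in place of 5-cyanopentyl on an aromatic carbon).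

Among the compounds with values here, three measured steps bear on this change, and all of them concern the chain that leaves. The first is a 2.3-fold lower number from compound 1 to compound 2 (0.36 log units; beyond the scatter), the next is a 2.7-fold lower number from compound 2 to compound 3 (0.43 log units; beyond the scatter), and together they span a 6.2-fold lower number from compound 1 to compound 3 (0.79 log units; beyond the scatter). Across these three compounds the number falls as the chain grows, and none goes against this. Within the data shown here, no measured compound has a ring at this place, so the effect of the entering group is unknown in this assay.

Removing the chain points upward, but the missing ring data argue against carrying over the full size of a 6.2-fold lower number from compound 1 to compound 3 (0.79 log units; beyond the scatter). A modest lean upward is therefore expected, and the expected change is a 1.7-fold higher number from compound 3 to compound 4 (0.22 log units; within the scatter). For compound 4 the estimated value is 10000 nM, with an expected range of 2500 nM to 35000 nM.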

Compound 4, solubility: < 1500 nM
Compound 4: a limit, no number; the forecaster's own chance of this, stated with the estimate: 5%; middle value at least 6.6-fold (0.82 log units) away from the limit.
By their numbers in this assay, from the lowest: compound 3; then compound 2; then compound 1. At a limit, below all of these: compound 4.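

In this assay compound 4 stands only as a limit of the assay, not as a number: the limit of < 1500 nM in this assay, at which 1 of the 4 values shown sits.

Even so, its steps can be read in one direction, as an at least 4.0-fold lower number from compound 3 to compound 4 (0.60 log units; beyond the scatter), an at least 10-fold lower number from compound 2 to compound 4 (1.02 log units; beyond the scatter) and an at least 24-fold lower number from compound 1 to compound 4 (1.39 log units; beyond the scatter). At this aromatic carbon, the heavy-atom count of the substituent therefore does not set the read-out on its own: the fall seen from methyl through 4-cyanobutyl to 5-cyanopentyl does not turn back with 1,3-thiazol-2-yl, which has fewer heavy atoms than 5-cyanopentyl yet sits under all three chain compounds.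

The compounds shown leave open how far compound 4 lies under its limit, and whether its place belongs to aromatic rings at this carbon in general or to 1,3-thiazol-2-yl alone. A phenyl or pyridin-2-yl ring, a saturated ring such as morpholine, or a chain ending in an amine or a carboxylic acid at the same carbon would separate these readings.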